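The compounds below may be only part of what the source reports. "The series", "measured", "known", "first", "only" and "open" are said of these compounds alone.

Measured compounds in an ADME assay on MDCK cells (Canis lupus familiaris) for cytotoxicity, read by microscopy, with a stated time of 48 h; on this read-out lower numbers stand for higher toxicity in this test and higher numbers for lower toxicity in this test. Compound 1, `CCCCc1csc(CN[C@@H]2C[C@H]3C[C@@H]([C@H]2C)C3(C)C)c1`, gives 12500 nM. Compound 2, `CCc1csc(CN[C@@H]2C[C@H]3C[C@@H]([C@H]2C)C3(C)C)c1`, gives 25000 nM. Compound 3, `C=Cc1ccsc1CN[C@@H]1C[C@H]2C[C@@H]([C@H]1C)C2(C)C`, gives 50000 nM.

On these numbers compound 2 stands second highest of the three, nearest to compound 1 and furthest from compound 3, both gaps within the scatter. The change from compound 2 to compound 4, `C[C@H]1[C@H](NCc2cc(Br)cs2)C[C@H]2C[C@@H]1C2(C)C`, is bromo in place of ethyl on an aromatic carbon. Among the measured compounds shown here, the only measured step at the same part of the structure is a 2.0-fold higher number from compound 1 to compound 2 (0.30 log units; within the scatter), where the ethyl was removed rather than replaced, and it stayed within the scatter. For the measured compounds named here, no measured step covers bromo on that ring carbon. Going by the values given here, with the one relevant step within the scatter, no step beyond the scatter is expected in this assay. Compound 4 is therefore estimated at 25000 nM, range 10000 nM to 60000 nM, which means an expected no change at the digits printed from compound 2 to compound 4 (within the scatter).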

Compound 4, minimum cytotoxic concentration: 6250 nM
Beside the measured number, compound 4's estimate is 4.0-fold (0.60 log units) above it, outside the stated range (below it).
By their numbers in this assay, from the lowest: compounds 4, 1, 2 and 3 (each within the scatter of the next, the first and the last beyond it).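

In this assay, among the compounds shown here, bromo in place of ethyl on this aromatic carbon gives a 4.0-fold lower number from compound 2 to compound 4 (0.60 log units; beyond the scatter) and is the one step at this position beyond the scatter, so a change here can move the read-out measurably. Bromo in place of butyl gives a 2.0-fold lower number from compound 1 to compound 4 (0.30 log units; within the scatter) and stays within the scatter, so the effect of bromo depends on which chain it is compared with. No evidence on the cause of either step is at hand. Open, from the compounds shown here alone, is whether chloro or a carboxylic acid on this carbon would give a step beyond the scatter, and whether a chain longer than butyl would.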